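This account rests on a few compounds, and the source may have more. Where it says the series, first, only, none or still open, it means among the compounds named here.

Measured so far in an ADME assay on J774.A1 cells (Mus musculus) for cytotoxicity, read by MTT assay; on this read-out higher numbers stand for lower toxicity in this test and lower numbers for higher toxicity in this test:
Compound 1, `O[C@H]1CCc2ccccc2[C@@H]1n1ccnn1`, gives 35.6 ug/mL.
Compound 2, `O=[N+]([O-])c1ccc(O[C@H]2CCc3ccccc3[C@@H]2n2ccnn2)c(F)c1`, gives > 100 ug/mL, which is a limit of the assay and not a number.
Compound 3, `O=[N+]([O-])c1ccc(O[C@H]2CCCC[C@@H]2n2ccnc2)cc1`, gives 8.27 ug/mL.

Among the two numbers given in this assay, compound 3 stands lowest, that is, it shows the higher toxicity in this test. Its nearest neighbour with a number is compound 1, and the gap between the two lies beyond the usual scatter of repeated measurements. Compound 2 sits at the limit of > 100 ug/mL in this assay, at which 1 of the 3 values shown sits, so only its limit is known.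

Compound 4, `O=[N+]([O-])c1ccc(O[C@H]2CCCC[C@@H]2n2ccnc2)c(F)c1`, differs from compound 3 in one place: fluoro in place of hydrogen on an aromatic carbon. Among the compounds with values here, no pair of measured compounds shows this same change on the same core, so there is no measured step to lean on. The step of a 1.7-fold higher number from compound 3 to compound 4 (0.23 log units; within the scatter) is expected to be modest, pointing toward a higher number, yet it may well stay within the scatter. For compound 4 the estimate in this assay is 14 ug/mL, with a range from 5 ug/mL to 45 ug/mL.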

Compound 4, half-maximal cytotoxic concentration: 14.3 ug/mL
Compound 4: middle estimate off by 1.0-fold (0.01 log units), on the low side, within the range that was stated.
By their numbers in this assay, from the lowest: compounds 3 and 4 (each within the scatter of the next); then compound 1. At a limit, above all of these: compound 2.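

Placing fluoro in place of hydrogen on an aromatic carbon, ortho to a large group and meta to a nitro group, gives a 1.7-fold higher number from compound 3 to compound 4 (0.24 log units; within the scatter) in this assay and provides the first direct reading of this change. Within the data shown here, the two compounds cannot be told apart in this test, so at this place on this core, the single fluorine brings no change that rises above the usual variation between repeated measurements. Nothing in the data gives a reason for this result.

Among these compounds, whether fluoro would behave the same way on another core remains open, since only this one pair shows the change. Also open, going by these compounds, is how this test would respond to a different group at the same place, such as an amine, a nitrile or a carboxylic acid.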